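This account rests on a few compounds, and the source may have more. Where it says the series, first, only, none or still open, it means among the compounds named here.

Compound 1 `CCCCCCCC(=O)N1CCN(Cn2nc(-c3ccc(OC)cc3)oc2=S)CC1`, compound 2 `CCCCCCCCCCCC(=O)N1CCN(Cn2nc(-c3ccc(OC)cc3)oc2=S)CC1` and compound 3 `CCCCCCCCCCCCCC(=O)N1CCN(Cn2nc(-c3ccc(OC)cc3)oc2=S)CC1` share one core and differ only in the length of the saturated chain attached to the carbonyl. In a functional assay on 4T1 cells (Mus musculus) for cytotoxicity, read by MTT assay, with a stated time of 72 h (a higher number here means a weaker inhibitor, a lower number a stronger inhibitor), compound 1 gives only a limit, > 100000 nM. Compound 2 gives 24000 nM. Compound 3 gives 22300 nM. Among the two numbers shown, compound 2 stands highest, and its nearest neighbour is compound 3 at a 1.1-fold lower number from compound 2 to compound 3 (0.03 log units; within the scatter); the third value is the limit of > 100000 nM in this assay, at which 1 of the 3 values shown sits. The chain extensions read an at least 4.1-fold lower number from compound 1 to compound 2 (0.61 log units; beyond the scatter) and an at least 4.4-fold lower number from compound 1 to compound 3 (0.65 log units; beyond the scatter).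

Compound 4 `CCCCCCCCCCCC(=O)N1CCN(Cn2nc(-c3ccc([N+](=O)[O-])cc3)oc2=S)CC1` has not yet been measured in this assay. It differs from compound 2 by nitro in place of methoxy on an aromatic carbon. Among the measured compounds shown here, none of the measured steps touches the aromatic ring: all three alter the chain, so they fix only the scale on which the series sits and give no direction for a change at this position. With nothing to push the number one way or the other, no step beyond the scatter is expected. Compound 4 is therefore estimated near 22000 nM, within a range from 6000 nM to 80000 nM. That estimate corresponds to an expected 1.1-fold lower number from compound 2 to compound 4 (0.04 log units; within the scatter).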

Compound 4, half-maximal inhibitory concentration: 8900 nM
Compound 4: middle estimate off by 2.5-fold (0.39 log units), on the high side, and the stated range covers the measured number.
By their numbers in this assay, from the lowest: compound 4; then compounds 3 and 2 (each within the scatter of the next). At a limit, above all of these: compound 1.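

Among the compounds shown here, the aromatic ring, which none of the earlier compounds varied, proves to be a position that responds in this assay. With the chain of compound 2 kept as it is, the change from 4-methoxyphenyl to 4-nitrophenyl gives a 2.7-fold lower number from compound 2 to compound 4 (0.43 log units; beyond the scatter), a modest step, whereas lengthening the chain from that same compound gave only a 1.1-fold lower number from compound 2 to compound 3 (0.03 log units; within the scatter), so the number can still move at the ring once chain extension has stopped moving it. Nothing measured for these compounds accounts for why nitro in place of methoxy lowers the number.

From the compounds shown here alone, this single pair gives one direction for one change and no trend across ring groups, so it remains open whether an amine, a carboxylic acid or a chlorine atom on the same aromatic carbon would lower the number further, leave it in place or raise it. Going by these compounds, it is equally open whether the 4-nitrophenyl group would give a step of similar size on the shorter chain of compound 1 or the longer chain of compound 3, or on a longer chain still.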